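A few compounds are considered here, and "the series" means these few. Any claim that something is new, unique, unknown or untested is made for them only; others in the source may bear on it.

Three compounds have been tested in a functional assay on the whole organism (Pleural cavity) for inhibition, with Rattus norvegicus as the target, at a dose of 25 mg/kg; a lower number here means less inhibition, a higher number more inhibition at the dose given (going by the name of the read-out):

compound 1 `CC1(Sc2ccccc2)C(=O)N(c2ccccc2)c2ncccc21` gives 0%;
compound 2 `CC1(C)C(=O)N(c2ccc(S(C)(=O)=O)cc2)c2ncccc21` gives 0%;
compound 3 `CSC1(C)C(=O)N(c2ccccc2)c2ncccc21` gives 53%.

Compound 2 stands level with compound 1 at the digits reported, the two together being the lowest of the three numbers; compound 3 is the furthest from it, with a number higher by an amount beyond the scatter. Within the data shown here, the only step measured between compounds that differ in a single place is a number 53 percentage points higher from compound 1 to compound 3 (beyond the scatter), a large rise brought by methyl in place of phenyl on a sulfur. Compound 4 `C[S+]([O-])c1ccc(N2C(=O)C(C)(C)c3cccnc32)cc1` differs from compound 2 as follows: a group of 3 heavy atoms (1 carbon, 1 oxygen, 1 sulfur; no ring) in place of a group of 4 heavy atoms (1 carbon, 2 oxygen, 1 sulfur; no ring), on an aromatic carbon. Among the measured compounds shown here, the measured step concerns the sulfur that carries the methyl or phenyl, not the group on the six-membered aromatic ring of carbon only, so it does not bear directly on this change, and no measured pair shows what replacing methylsulfonyl does. With nothing pointing in either direction, the expected step is a number 8 percentage points higher from compound 2 to compound 4 (within the scatter), within the scatter. Compound 4 is therefore estimated at 8%, in the range 0% to 35%.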

Compound 4, a percentage reported as inhibition, in the whole organism at one dose (the size of the read-out at that dose, not a potency): 0%
For compound 4 the middle estimate is 8 percentage points above the measured one; the measured number falls inside the stated range.
By their numbers in this assay, from the lowest: compounds 1, 2 and 4 (each within the scatter of the next); then compound 3.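

At the place on the six-membered aromatic ring of carbon only, para to a large group, putting the group of 3 heavy atoms where methylsulfonyl stood gives, in this assay, no change at the digits printed from compound 2 to compound 4 (within the scatter). Both readings lie at the bottom of the scale, so this pair cannot show whether either sulfur group comes closer to giving inhibition at this dose. Nothing available on these compounds offers an explanation for this result.

Still open, going by these compounds, is whether either of these two groups would behave the same way on the core of compound 3, which keeps a methyl on its sulfur. On these data alone, it is also open whether a quite different group at this place, such as an amine or a carboxylic acid, would give a reading above the bottom of the scale.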